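The source may hold more compounds than are shown below. What is called first, only, known or untested is meant among the compounds shown, and "the series" means these compounds.

Measured in a functional assay on HT-29 cells (Homo sapiens) for antiproliferative activity, read by sulforhodamine B assay, with a stated time of 48 h; a lower number here means a stronger inhibitor, a higher number a weaker inhibitor:
- compound 1 `CCN1CCN(c2ccc(S(=O)(=O)Oc3cccc(Br)c3)cc2)C1=O`: 3800 nM
- compound 2 `CCCCN1CCN(c2ccc(S(=O)(=O)Oc3ccccc3OC)cc2)C1=O`: > 100000 nM (a limit, not a number)

Compound 2 has only a limit and no number: the limit of > 100000 nM in this assay, at which 1 of the 2 values shown sits. Its true position in this assay is therefore open on the weak side, and any step away from it can only be estimated.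

Compound 3 `CCCCN1CCN(c2ccc(S(=O)(=O)Oc3cccc(Br)c3)cc2)C1=O` is unmeasured. It differs from compound 2 by 3-bromophenyl in place of 2-methoxyphenyl on an oxygen. Within the data shown here, no measured step isolates this change, so the expectation rests on a single comparison. Compound 1 carries the same 3-bromophenyl on that oxygen and gives a real number, 3800 nM. A clear gain in potency is therefore expected, well beyond the scatter, though compound 3 could still stay at the limit, and this is kept as a small chance. The expected change is an at least 25-fold lower number from compound 2 to compound 3 (1.39 log units; beyond the scatter), towards a lower number and so a stronger inhibitor. For compound 3 the estimated value is 4000 nM, with an expected range of 1000 nM to 20000 nM.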

Compound 3, half-maximal inhibitory concentration: 16000 nM
For compound 3 the middle estimate is 4.0-fold (0.60 log units) below the measured one; the range from low to high includes it.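

In this assay, 3-bromophenyl in place of 2-methoxyphenyl on the oxygen bound to the sulfonyl sulfur gives an at least 6.2-fold lower number from compound 2 to compound 3 (0.79 log units; beyond the scatter), so with the chain of compound 2 held constant, this one change is enough to yield a measurable value. From the compounds shown here alone, compound 2 is a limit and not a number, so the true size of that step stays open: the limit of > 100000 nM in this assay, at which 1 of the 3 values shown sits. Among these compounds, with 3-bromophenyl held constant, ethyl in place of hydrogen on a saturated chain carbon, two bonds along the chain from an amide-type nitrogen in a ring, gives a 4.2-fold higher number from compound 1 to compound 3 (0.62 log units; beyond the scatter), which is the first direct reading of the chain at this position and shows that the longer chain of compound 3 is the less potent of the two in this pair.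

The compounds shown leave open whether the gain follows from the bromine, from the loss of the methoxy group, or from where either substituent sits, and a plain phenyl, a 3-methoxyphenyl or a 2-bromophenyl on that oxygen would help separate these. Going by these compounds, how a methyl or a hexyl chain would read at the other position, and whether the chain step holds with 2-methoxyphenyl on the oxygen, also remains open.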